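The source may hold more compounds than are shown below. What is called first, only, known or untested is meant among the compounds shown, and "the series" means these compounds.

Compound 1 `COc1ccc(-c2cnc(NC(=O)c3cnco3)n2C)cc1` is the reference point here. In a toxicity assay on THP-1 cells (Homo sapiens) for inhibition (on this read-out higher numbers stand for lower toxicity in this test and lower numbers for higher toxicity in this test), compound 1 reaches only the assay limit, > 100000 nM, not a numerical value. Compound 2 `COc1ccc(-c2cnc(NC(=O)c3ccc(F)cc3)n2C2CCCC2)cc1` also gives a limit in this assay, > 100000 nM. Every value shown so far is therefore a limit, as the limit of > 100000 nM in this assay, at which 2 of the 2 values shown sit, records, and compound 1 stands exactly where the rest of the set stands. Compound 3 `COc1ccc(-c2cnc(NC(=O)c3ccn[nH]3)n2C)cc1` differs from compound 1 by 1H-pyrazol-5-yl in place of 1,3-oxazol-5-yl on a carbonyl carbon. Going by the values given here, no measured step bears on this change; the expected step from compound 1 to compound 3 in this assay is none beyond the scatter, a step that the limit leaves unreadable from compound 1 to compound 3. Compound 3 is accordingly estimated at 150000 nM in this assay, within 60000 nM to 400000 nM.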

Compound 3, half-maximal cytotoxic concentration: > 100000 nM
Compound 3: only a limit was reported; the forecaster's own chance of this, stated with the estimate: 85%; the middle value lies beyond the limit too.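

Compound 1 and compound 3 both stand at a limit, so no step can be read between them: the limit of > 100000 nM in this assay, at which 3 of the 3 values shown sit.

The compounds shown leave open whether 1H-pyrazol-5-yl and 1,3-oxazol-5-yl on a carbonyl carbon differ at all in this assay.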